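The compounds below may be only part of what the source reports. "The series", "measured", "known", "first", "only" and "open" are said of these compounds alone.

Compound 1, `CCN(CC)C(=O)CC1CCc2cc(OC)c(OC)cc21`: in a functional assay on the whole organism (strain Swiss albino) for inhibition, with Mus musculus as the target, in the writhing test, with stated times of 60 min and 15 min, at a dose of 100 mg/kg by the oral route (a lower number here means less inhibition, a higher number more inhibition at the dose given (going by the name of the read-out)), compound 1 gives 27.4%.
Compound 2, `CCCCCCNC(=O)CC1CCc2cc(OC)c(OC)cc21`: in this assay compound 2 gives 82.2%.
Compound 3, `COc1cc2c(cc1OC)C(CC(=O)NC1CCCCC1)CC2`: in this assay compound 3 gives 44.7%.

Compound 3 stands second highest of the three numbers. Its nearest neighbour is compound 1, with a number 17.3 percentage points higher from compound 1 to compound 3 (beyond the scatter); its furthest is compound 2, with a number 37.5 percentage points lower from compound 2 to compound 3 (beyond the scatter). Compound 4, `COc1cc2c(cc1OC)C(CC(=O)NCCO)CC2`, has not yet been measured in this assay. It differs from compound 3 at the amide-type nitrogen: 2-hydroxyethyl in place of cyclohexyl on an amide-type nitrogen.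

For the measured compounds named here, the steps that bear on this change are the other exchanges at the same position: a number 54.8 percentage points higher from compound 1 to compound 2 (beyond the scatter) and a number 37.5 percentage points lower from compound 2 to compound 3 (beyond the scatter), both beyond the scatter, and the smaller a number 17.3 percentage points higher from compound 1 to compound 3 (beyond the scatter). Going by the values given here, these show that the group on the amide-type nitrogen moves the inhibition strongly, yet no measured compound carries a 2-hydroxyethyl group, or any group with a hydrogen-bond donor, at that place, so the direction of the step is not fixed by these data. A step beyond the scatter in either direction is therefore possible, and the estimate is held near the middle of the measured spread. For compound 4 the expected value is 40%, within a range from 15% to 70%. The step this estimate implies is expected to be a number 4.7 percentage points lower from compound 3 to compound 4 (within the scatter).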

Compound 4, a percentage reported as inhibition, in the whole organism at one dose (the size of the read-out at that dose, not a potency): 29.8%
Estimate against measurement, compound 4: 10.2 percentage points above; measured number inside the range.
By their numbers in this assay, from the lowest: compounds 1 and 4 (each within the scatter of the next); then compound 3; then compound 2.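

In this assay, the 2-hydroxyethyl group gives the first read on a hydroxy-bearing chain on the amide-type nitrogen, and it falls short of both cyclohexyl (a number 14.9 percentage points lower from compound 3 to compound 4 (beyond the scatter)) and hexyl (a number 52.4 percentage points lower from compound 2 to compound 4 (beyond the scatter)). Against the diethylamino amide it shows no separable difference (a number 2.4 percentage points higher from compound 1 to compound 4 (within the scatter)), so an amide hydrogen on that nitrogen does not by itself lift the number above that of compound 1, and among these compounds a high number stays with the hexyl chain of compound 2. Nothing in hand accounts for this order.

On these data alone, it remains open whether a butyl or octyl chain would hold the number of compound 2. As far as these compounds go, it is also open whether a longer chain ending in hydroxy, or a chain ending in an amine or a carboxylic acid, would behave like compound 4.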